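The compounds below may be only part of what the source reports. "The series", "measured", "known", "first", "only" and "open" are said of these compounds alone.

Measured in a functional assay on HCT-116 cells (Homo sapiens) for inhibition; on this read-out higher numbers stand for weaker inhibition and lower numbers for stronger inhibition:
- compound 1 `CC(C)=CCC/C(C)=C/C[C@]12C(=O)CC(=O)[C@](CC=C(C)C)(C[C@@H](CC=C(C)C)C1(C)C)C2=O`: 10.9 ug/mL
- compound 2 `CC(C)=CCC/C(C)=C/C[C@@H]1C[C@]2(C/C=C(\C)CCC=C(C)C)C(=O)[C@@](CC=C(C)C)(C(=O)C(C(=O)c3ccc(O)c(O)c3)=C2O)C1(C)C`: 4.92 ug/mL

Compound 1 has the higher of the two numbers, which means weaker inhibition, and the gap down to compound 2 lies beyond the scatter.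

Compound 3 `CC(C)=CCC/C(C)=C/C[C@]12C[C@@H](CC=C(C)C)C(C)(C)[C@](C/C=C(\C)CCC=C(C)C)(C(=O)CC1=O)C2=O` departs from compound 1 by 3-methylbut-2-en-1-yl in place of hydrogen on a saturated chain carbon bound to a double-bonded chain carbon. That is 3-methylbut-2-en-1-yl in place of hydrogen on a saturated chain carbon bound to a double-bonded chain carbon, so a 3-methylbut-2-en-1-yl chain becomes 3,7-dimethylocta-2,6-dien-1-yl.

Among the measured compounds shown here, no measured pair differs in one place, so nothing shows what such a change does in this assay. The expectation therefore stays anchored on compound 1 at 10.9 ug/mL, with no step beyond the scatter. The expected change is a 1.2-fold lower number from compound 1 to compound 3 (0.08 log units; within the scatter). For compound 3 the estimated value is 9 ug/mL, with an expected range of 4 ug/mL to 20 ug/mL.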

Compound 3, half-maximal inhibitory concentration: > 20 ug/mL
Compound 3: only a limit was reported; the forecaster's own chance of this, stated with the estimate: 8%; at least 2.2-fold (0.34 log units) between middle value and limit.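

In this assay compound 3 gives > 20 ug/mL, a limit of the assay and not a number. Hydrogen replaced by 3-methylbut-2-en-1-yl on a saturated chain carbon bound to a double-bonded chain carbon, turning a 3-methylbut-2-en-1-yl chain into 3,7-dimethylocta-2,6-dien-1-yl, gives the only step in the series, with an at least 1.8-fold higher number from compound 1 to compound 3 (0.26 log units; that floor lies within the scatter). On these data alone, this longer chain therefore brings no gain in inhibition, yet the floor of the step does not by itself separate the two compounds and the full size of the step remains unknown: the limit of > 20 ug/mL in this assay, at which 1 of the 3 values shown sits.

As far as these compounds go, whether a shorter chain such as ethyl, or a chain ending in an amine or a carboxylic acid, would change inhibition at this place remains open. From the compounds shown here alone, whether the true step lies beyond the scatter also remains open.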